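Working notes: compound 4 from compound 3 in the sulfonamide series

A few compounds are considered here, and "the series" means these few. Any claim that something is new, unique, unknown or untested is made for them only; others in the source may bear on it.

Compound 1 `O=S(=O)(Nc1ccc(-c2nc3ccccc3o2)cc1)c1ccccc1F`, compound 2 `O=S(=O)(Nc1ccc(-c2nc3ccccc3o2)cc1)c1ccc(O)cc1` and compound 3 `COc1ccc(S(=O)(=O)Nc2ccc(-c3nc4ccccc4o3)cc2)cc1` share one core and differ only in the aryl group on the sulfonyl sulfur. In an assay on isolated protein for inhibition of malate dehydrogenase, mitochondrial (Sus scrofa), with stated times of 45 min and 30 min (a higher number here means a weaker inhibitor, a lower number a stronger inhibitor), compound 1 gives > 63000 nM, which is a limit of the assay and not a number. In this assay compound 2 gives > 63000 nM, likewise a limit. In this assay compound 3 gives > 63000 nM, again a limit. Compound 3 therefore stands only at a limit, as do the other two, all at the limit of > 63000 nM in this assay, at which 3 of the 3 values shown sit. The steps a step that the two limits leave unreadable from compound 1 to compound 2, a step that the two limits leave unreadable from compound 1 to compound 3 and a step that the two limits leave unreadable from compound 2 to compound 3 have no readable size because the limit of > 63000 nM in this assay, at which 3 of the 3 values shown sit, holds both ends of each.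

Compound 4 `COc1cccc(S(=O)(=O)Nc2ccc(-c3nc4ccccc4o3)cc2)c1` is not yet measured; it differs from compound 3 by 3-methoxyphenyl in place of 4-methoxyphenyl on a sulfonyl sulfur. Every measured step that bears on a change of the aryl group on the sulfonyl sulfur sits at the limit, so no size or direction can be read from them. The expected step is therefore a step that the limit leaves unreadable from compound 3 to compound 4 in this assay, meaning no readable change and most likely a further limit. Compound 4 is expected at 100000 nM in this assay, with a range from 40000 nM to 300000 nM.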

Compound 4, half-maximal inhibitory concentration: > 63000 nM
Compound 4 was reported as a limit (the forecaster's own chance of this, stated with the estimate: 85%); the middle value lies beyond the limit too.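

In this assay compound 4 gives > 63000 nM, a limit and not a number. No step from compound 1, compound 2 or compound 3 to compound 4 can be read: the limit of > 63000 nM in this assay, at which 4 of the 4 values shown sit.

The compounds shown leave open whether any aryl group on the sulfonyl sulfur gives a measurable value in this assay, and how 3-methoxyphenyl and 4-methoxyphenyl compare.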